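Phenyl for methyl on the acylguanidine side chain

The source may hold more compounds than are shown below. What is called first, only, known or untested is meant among the compounds shown, and "the series" means these compounds.

Compound 2 `CC(CC(=O)/N=C(\N)NCCCn1ccnc1)c1ccccc1` stands lowest of the two numbers measured in an assay on ileum for antagonist activity at histamine H1 receptor (Cavia porcellus), with a stated time of 15 min; a lower number here means tighter binding, a higher number weaker binding; in this assay compound 2 gives 1120 nM. Among the compounds with values here, its neighbour, compound 1 `CC(CC(=O)/N=C(\N)NCCCc1ccc(CN(C)C)o1)c1ccccc1`, gives 3020 nM in this assay, and the step of a 2.7-fold lower number from compound 1 to compound 2 (0.43 log units; beyond the scatter) is the only measured step in the set.

Compound 3 `N/C(=N\C(=O)CC(c1ccccc1)c1ccccc1)NCCCn1ccnc1` differs from compound 2 by phenyl in place of methyl on a saturated chain carbon bound to an aromatic carbon and a saturated chain carbon. Within the data shown here, the single measured step, from compound 1 to compound 2, concerns the group three bonds along the chain from an amine nitrogen, not the saturated chain carbon bound to an aromatic carbon where the present change sits, so it does not bear on it. Among the measured compounds shown here, no measured pair shows what a phenyl in place of a methyl at this place does in this assay.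

In the absence of a comparable step, the expected step from compound 2 to compound 3 is a 1.9-fold lower number from compound 2 to compound 3 (0.27 log units; within the scatter), kept small. Compound 3 is therefore expected to give 600 nM in this assay, in a range from 150 nM to 2500 nM.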

Compound 3, dissociation constant: 2340 nM
The estimate for compound 3 lay 3.9-fold (0.59 log units) below the measured number, within the range that was stated.
By their numbers in this assay, from the lowest: compound 2; then compounds 3 and 1 (each within the scatter of the next).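

In this assay, phenyl in place of methyl on a saturated chain carbon bound to an aromatic carbon and a saturated chain carbon gives a 2.1-fold higher number from compound 2 to compound 3 (0.32 log units; beyond the scatter), so this place in the molecule does respond to the change, modestly and towards weaker binding. Within the data shown here, until now the only measured change was the one three bonds along the chain from an amine nitrogen, a 2.7-fold lower number from compound 1 to compound 2 (0.43 log units; beyond the scatter), and compound 3 shows that the number also moves on the other side of the molecule, where the larger aromatic group brought no gain over methyl in this assay. Nothing available accounts for this loss, and no measurement of any property of these compounds bears on it.

With a single replacement shown at this place, it remains open whether a smaller or a saturated group, such as a hydrogen atom, an ethyl or a cyclohexyl, would lower or raise the number. On these data alone, it is also open whether phenyl in place of methyl would give a step of similar size with the 5-((dimethylamino)methyl)furan-2-yl group of compound 1 in place of the 1H-imidazol-1-yl group.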